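Replacing a urea with a tertiary acetamide on the side chain

A few compounds are considered here, and "the series" means these few. Any claim that something is new, unique, unknown or untested is made for them only; others in the source may bear on it.

Compound 3 `NC(=O)NC[C@@H]1CCCc2cc(S(=O)(=O)c3cccc(F)c3)ccc21`: 0.2 nM
Compound 2 `N=C(N)NC(=O)C[C@@H]1CCCc2cc(S(=O)(=O)c3cccc(F)c3)ccc21`: 0.631 nM
Compound 1 `O=S(=O)(O)CCCNC[C@@H]1CCCc2cc(S(=O)(=O)c3cccc(F)c3)ccc21`: 1.26 nM

In an assay on isolated protein for displacement of a labelled ligand from 5-hydroxytryptamine receptor 6 (Homo sapiens) (on this read-out lower numbers stand for stronger inhibition and higher numbers for weaker inhibition), compound 3 gives the lowest of the three numbers. The steps of a 3.2-fold lower number from compound 2 to compound 3 (0.50 log units; beyond the scatter) and a 6.3-fold lower number from compound 1 to compound 3 (0.80 log units; beyond the scatter) both lie beyond the scatter, so compound 3 is the most potent of the set, whereas the step of a 2.0-fold lower number from compound 1 to compound 2 (0.30 log units; within the scatter) is within the scatter. Compound 4 `CC(=O)N(C)C[C@@H]1CCCc2cc(S(=O)(=O)c3cccc(F)c3)ccc21` carries acetyl(methyl)amino in place of ureido on a saturated chain carbon bound to a saturated ring carbon. Going by the values given here, both measured steps into compound 3 swapped a larger side-chain group for a smaller one and lowered the number, but no measured step takes away the hydrogen-bond donors of the urea, so the new change is not covered by earlier data. Compound 4 is therefore expected to give a modestly higher number, an estimated step of a 5.0-fold higher number from compound 3 to compound 4 (0.70 log units; beyond the scatter). The estimate for compound 4 is 1 nM, with a range from 0.2 nM to 5 nM.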

Compound 4, inhibition constant: 1.59 nM
The estimate for compound 4 lay 1.6-fold (0.20 log units) below the measured number, and the stated range covers the measured number.
By their numbers in this assay, from the lowest: compound 3; then compounds 2, 1 and 4 (each within the scatter of the next, the first and the last beyond it).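

In this assay, exchanging ureido for acetyl(methyl)amino removes the hydrogen-bond donors at this position and gives an 8.0-fold higher number from compound 3 to compound 4 (0.90 log units; beyond the scatter). The side chain of compound 2 also keeps a lower number, with a 2.5-fold higher number from compound 2 to compound 4 (0.40 log units; beyond the scatter), whereas a 1.3-fold higher number from compound 1 to compound 4 (0.10 log units; within the scatter) stays within the scatter, so compound 1 and compound 4 cannot be told apart here. No measured evidence bears on the reason for these steps. On these data alone, what stays open is which part of the exchange counts: a secondary acetamide, which keeps the amide hydrogen and lacks the methyl on nitrogen, would separate the two.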